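The compounds below may be only part of what the source reports. "The series", "measured", "known", "first", "only" and "open" are said of these compounds alone.

Working notes on the series:

- compound 1 `COc1cccc(CSc2nnc([C@@H](C)c3ccc4cc(OC)ccc4c3)n2-c2ccc(Cl)cc2)c1`: 138000 nM
- compound 2 `COc1ccc2cc([C@H](C)c3n[nH]c(=S)n3-c3cccc(Cl)c3)ccc2c1`: "not determined" (no result reported)
- compound 3 `COc1ccc2cc([C@H](C)c3nnc(SCc4c(C)cc(C)cc4C)n3-c3ccc(F)cc3)ccc2c1`: 43300 nM
- compound 4 `COc1ccc2cc([C@H](C)c3nnc(SCc4c(Cl)cccc4Cl)n3-c3ccc(Cl)cc3)ccc2c1`: awaiting measurement

The read-out is a functional assay on PC-3 cells (Homo sapiens) for cytotoxicity, read by MTT assay; a higher number here means a weaker inhibitor, a lower number a stronger inhibitor. Compound 1, at 138000 nM, holds the higher of the two numbers available. Compound 3 gives 43300 nM, a lower number by more than the usual scatter. Compound 2 has no reported result and offers no comparison.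

Compound 4 follows from compound 1 by one change: 2,6-dichlorophenyl in place of 3-methoxyphenyl on a saturated chain carbon bound to a sulfur. In words, 2,6-dichlorophenyl stands in place of 3-methoxyphenyl on a saturated chain carbon bound to a sulfur. Going by the values given here, no measured pair isolates this kind of change, so the expectation is loose. Among the compounds with values here, compound 3, at 43300 nM, suggests only that a number lower than that of compound 1 is possible, and it differs from compound 1 in more than one place. The expected change is modest and downward, given as a 2.3-fold lower number from compound 1 to compound 4 (0.36 log units; beyond the scatter). For compound 4 the estimated value is 60000 nM, with an expected range of 20000 nM to 150000 nM.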

Compound 4, half-maximal inhibitory concentration: 34700 nM
Compound 4: the middle estimate sits 1.7-fold (0.24 log units) above what was measured, and the stated range covers the measured number.
By their numbers in this assay, from the lowest: compounds 4 and 3 (each within the scatter of the next); then compound 1.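

In this assay, going by these compounds alone, the exchange of 3-methoxyphenyl for 2,6-dichlorophenyl on a saturated chain carbon bound to a sulfur gives a 4.0-fold lower number from compound 1 to compound 4 (0.60 log units; beyond the scatter) and is the first change at a single place that can be read. The number at this position therefore responds to the identity of the aromatic group, even though both groups have 8 heavy atoms and one six-membered aromatic ring of carbon only. No measurement on hand accounts for the step.

The compounds shown do not separate the loss of the methoxy group from the gain of the two chlorines, as no compound carries an unsubstituted phenyl or a single chlorine there. Going by these compounds, it also remains open how the number would respond to an amine, a carboxylic acid or a longer chain in place of the 2,6-dichlorobenzyl group.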